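Aryloxy halogen pattern and antiproliferative potency

The source may hold more compounds than are shown below. What is called first, only, known or untested is meant among the compounds shown, and "the series" means these compounds.

Compound 3 `NC1=NC2(CCOCC2)N(OCCCOc2ccccc2Br)C(N)=N1` gives 30 nM in a functional assay on HCT-116 cells (Homo sapiens) for antiproliferative activity, read by MTT assay, with a stated time of 72 h (a lower number here means a stronger inhibitor, a higher number a weaker inhibitor), the lowest number of the three measured compounds; compound 1 `NC1=NC2(CCOCC2)N(OCCCOc2ccc(Cl)c(Cl)c2)C(N)=N1` gives 90 nM and compound 2 `NC1=NC2(CCOCC2)N(OCCCOc2cc(Cl)c(Cl)cc2Cl)C(N)=N1` gives 2750 nM in this assay. The step to compound 4 `NC1=NC2(CCOCC2)N(OCCCOc2ccc(Cl)cc2Cl)C(N)=N1` is 2,4-dichlorophenyl in place of 2-bromophenyl on an oxygen on a saturated carbon. Among the compounds with values here, three measured steps bear on it. a 3.0-fold lower number from compound 1 to compound 3 (0.48 log units; beyond the scatter) and a 92-fold lower number from compound 2 to compound 3 (1.96 log units; beyond the scatter) show that the 2-bromophenyl gives lower numbers than either chlorinated ring already in hand, and a 31-fold higher number from compound 1 to compound 2 (1.49 log units; beyond the scatter) shows that chloro in place of hydrogen on an aromatic carbon of compound 1 raises the number sharply. Compound 4 carries 2,4-dichlorophenyl, a chlorine pattern that sits between compound 1 and compound 2, so a higher number than compound 3 is expected in this assay, of a size between the modest and the large steps seen. The estimated step is a 6.7-fold higher number from compound 3 to compound 4 (0.82 log units; beyond the scatter). Compound 4 is expected to give about 200 nM, plausibly between 40 nM and 1500 nM.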

Compound 4, half-maximal inhibitory concentration: 880 nM
The estimate for compound 4 lay 4.4-fold (0.64 log units) below the measured number, and the stated range covers the measured number.
By their numbers in this assay, from the lowest: compound 3; then compound 1; then compound 4; then compound 2.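

In this assay, the 2,4-dichlorophenyl ring does not keep the low number of the 2-bromophenyl ring on this oxygen (a 29-fold higher number from compound 3 to compound 4 (1.47 log units; beyond the scatter)). The arrangement of the chlorines matters as well as their presence, as the two dichlorophenyl rings are clearly separated (a 9.8-fold higher number from compound 1 to compound 4 (0.99 log units; beyond the scatter)). Removing one chloro from the ring of compound 2 recovers only part of the loss (a 3.1-fold lower number from compound 2 to compound 4 (0.49 log units; beyond the scatter)), so that chloro alone does not account for the high number of compound 2.

A 2-chlorophenyl ring would show how much of the step from compound 3 to compound 4 belongs to the change of halogen and how much to the added chloro, and a 2,4-dibromophenyl ring would test the same pattern with bromine. No measurement here gives a cause for any of these steps.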